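The compounds below may be only part of what the source reports. "The series", "measured", "known", "first", "only" and "open" are said of these compounds alone.

Measured in an ADME assay on HepG2 cells (Homo sapiens) for cytotoxicity, read by luminescence, with a stated time of 72 h; a lower number here means that less compound is needed, a higher number that more compound is needed for the effect:
- compound 1 `CCOC(=O)c1c(-c2cccc(OC)c2)[nH]c2cc(OC)ccc2c1=O`: > 21500 nM (a limit)
- compound 2 `CCOC(=O)c1c(-c2cccc(Br)c2)[nH]c2cc(OC)ccc2c1=O`: > 21500 nM (a limit)

Compound 2 has no numerical value, only the limit of > 21500 nM. Compound 3 `CCOC(=O)c1c(-c2cccc(N(C)C)c2)[nH]c2cc(OC)ccc2c1=O` differs from compound 2 by one change, dimethylamino in place of bromo on an aromatic carbon. Among the measured compounds shown here, the only measured step bearing on this is a step that the two limits leave unreadable from compound 1 to compound 2, and it gives no size or direction. Both measured compounds rest at the limit of > 21500 nM in this assay, at which 2 of the 2 values shown sit. In this assay, therefore, no step beyond the scatter can be expected, and the expected step is a step that the limit leaves unreadable from compound 2 to compound 3. Compound 3 is estimated at 22000 nM, within an expected range of 8000 nM to 40000 nM.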

Compound 3, half-maximal effective concentration: > 21500 nM
Compound 3 was reported as a limit; the forecaster's own chance of this, stated with the estimate: 75%; the middle value does not contradict the limit.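

In this assay, among the compounds shown here, compound 1, compound 2 and compound 3 are all reported only as limits, so no step among them can be read: the limit of > 21500 nM in this assay, at which 3 of the 3 values shown sit. From the compounds shown here alone, how far their true values lie from one another, and whether any differ at all, remains open.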